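Cyclobutyl in place of isopropyl on the shared core

A few compounds are considered here, and "the series" means these few. Any claim that something is new, unique, unknown or untested is made for them only; others in the source may bear on it.

In a functional assay (aorta) with Oryctolagus cuniculus as the target (on this read-out lower numbers stand for tighter binding and higher numbers for weaker binding), compound 3 (`Cc1ccnc2c1nc(C(C)C)n2Cc1ccc(-c2ccccc2C(=O)O)cc1`) gives 31.6 nM, within the scatter of compound 2 (`Cc1ccnc2c1nc(C)n2Cc1ccc(-c2ccccc2C(=O)O)cc1`) at 50.1 nM. Compound 1 (`CCCc1nc2c(C)ccnc2n1Cc1ccc(-c2ccccc2C(=O)O)cc1`), with propyl at the same carbon, gives 3.16 nM; 3.16 nM (2 entries), a lower number than either. Compound 4 (`Cc1ccnc2c1nc(C1CCC1)n2Cc1ccc(-c2ccccc2C(=O)O)cc1`) carries cyclobutyl in place of isopropyl on an aromatic carbon. Going by the values given here, the only measured step at this carbon, a 1.6-fold lower number from compound 2 to compound 3 (0.20 log units; within the scatter), stays within the scatter and is a different change. The value of compound 1, 3.16 nM; 3.16 nM (2 entries), leaves room for a lower number in this assay. The estimated step is small, toward a lower number and close to the scatter: a 2.0-fold lower number from compound 3 to compound 4 (0.30 log units; within the scatter). Compound 4 is estimated at 16 nM, with an expected range of 5 nM to 50 nM.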

Compound 4, dissociation constant: 5.01 nM
Compound 4: middle estimate off by 3.2-fold (0.50 log units), on the high side; the range from low to high includes it.
By their numbers in this assay, from the lowest: compound 4; then compounds 3 and 2 (each within the scatter of the next).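

Cyclobutyl at this carbon, between two ring nitrogen atoms, gives the first step here that lies beyond the scatter: a 6.3-fold lower number from compound 3 to compound 4 (0.80 log units; beyond the scatter) in this assay. Against methyl the change is a 10-fold lower number from compound 2 to compound 4 (1.00 log units; beyond the scatter), whereas isopropyl stayed within the scatter of methyl, so at this carbon the exchange of methyl reads differently for these two groups. No measurement on hand accounts for the gap between cyclobutyl and isopropyl.

Open, as far as these compounds go, is how the number runs with ring size, from cyclopropyl to cyclopentyl. Also open, from the compounds shown here alone, is how a longer chain such as butyl, or an amine, would read at this carbon.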